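Trimming the long chain of compound 2

The compounds below may be only part of what the source reports. "The series", "measured", "known", "first", "only" and "open" are said of these compounds alone.

Of the compounds shown here, two with a shared core have numbers so far. In a functional assay, read by fluorescence and spectrophotometry, with a stated time of 1 h (a higher number here means that more compound is needed for the effect, a lower number that less compound is needed), compound 1 (`O=S(=O)(/C=C/c1ccc(O)c(O)c1)CC1CCC1`) gives 8800 nM and compound 2 (`CCCCCCCCCCCS(=O)(=O)/C=C/c1ccc(O)c(O)c1`) gives 11400 nM. These two values lie within the usual scatter of repeated measurements, so neither can be ranked above the other. Compound 3 (`CCCCCCCS(=O)(=O)/C=C/c1ccc(O)c(O)c1`) alters compound 2 in one place: hydrogen in place of butyl on a saturated chain carbon, seven bonds along the chain from a sulfonyl sulfur, which is hydrogen in place of butyl on a saturated chain carbon, seven bonds along the chain from a sulfonyl sulfur. Going by the values given here, no measured pair shows this change on its own, so any forecast in this assay is loose. Compound 1 at 8800 nM and compound 2 at 11400 nM carry different groups yet fall within the scatter of each other, so no step beyond the scatter is expected. The estimated step of a 1.3-fold lower number from compound 2 to compound 3 (0.10 log units; within the scatter) is therefore small. The expected value for compound 3 is 9000 nM, with an estimated range from 3500 nM to 23000 nM.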

Compound 3, half-maximal effective concentration: 7100 nM
Compound 3: the middle estimate sits 1.3-fold (0.10 log units) above what was measured; low and high end bracket the measured number.
By their numbers in this assay, from the lowest: compounds 3, 1 and 2 (each within the scatter of the next).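

In this assay, going by these compounds alone, hydrogen in place of butyl on a saturated chain carbon, seven bonds along the chain from a sulfonyl sulfur, gives a 1.6-fold lower number from compound 2 to compound 3 (0.21 log units; within the scatter), so cutting the chain back at this position produces no step that can be told from repeat-measurement noise. Hexyl in place of cyclobutyl on a saturated chain carbon bound to a sulfonyl sulfur gives a 1.2-fold lower number from compound 1 to compound 3 (0.09 log units; within the scatter), so at that carbon the open chain and the ring cannot be told apart either. Nothing measured alongside these numbers accounts for how little they differ.

From the compounds shown here alone, whether an amine or a carboxylic acid in place of these carbon groups would give a step beyond the scatter remains open. So does the effect of a much shorter chain, such as ethyl, on the shared core.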